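Trimming a methoxy from a weak receptor antagonist

The compounds below may be only part of what the source reports. "The series", "measured", "known", "first", "only" and "open" are said of these compounds alone.

Measured compounds:
compound 1: `COc1nn2cc(-c3cc4c(OC)ccc(OC)c4o3)nc2s1`, 10000 nM
compound 2: `COc1cc(OCc2cccc(Sc3ccccc3)c2)c2cc(-c3cn4nc(OC)sc4n3)oc2c1`, 410 nM

In an assay on a cell-free system (plasma) for antagonist activity at proteinase-activated receptor 4 (Homo sapiens), with a stated time of 5 min, in the presence of a further agent that is not named here (on this read-out higher numbers stand for weaker inhibition and lower numbers for stronger inhibition), compound 1 gives 10000 nM, the highest of the two numbers recorded. Compound 2 gives 410 nM in this assay, a far lower number, and the gap lies beyond the usual scatter; the two compounds differ in several places, so nothing more can be read from them as a pair. Compound 3, `COc1nn2cc(-c3cc4c(OC)cccc4o3)nc2s1`, has not yet been measured. It differs from compound 1 in one place: hydrogen in place of methoxy on an aromatic carbon. Going by the values given here, no single-change step between measured compounds exists to set the size of such a change, so any expectation rests on compound 1 alone. Because compound 1 already gives 10000 nM, little room for further weakening remains. The step from compound 1 to compound 3 in this assay is expected to be no change at the digits printed from compound 1 to compound 3 (within the scatter), nothing beyond the scatter. Compound 3 is estimated at 10000 nM, within a range from 3000 nM to 30000 nM.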

Compound 3, half-maximal inhibitory concentration: 1300 nM
Estimate against measurement, compound 3: 7.7-fold (0.89 log units) above; the whole stated range lies above it.
By their numbers in this assay, from the lowest: compound 2; then compound 3; then compound 1.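

In this assay, swapping this methoxy for hydrogen gives a 7.7-fold lower number from compound 1 to compound 3 (0.89 log units; beyond the scatter). Going by these compounds alone, this is the first single-change step in the set, and it shows that the methoxy on this aromatic carbon, para to a methoxy group, is not needed for the activity measured here: the compound inhibits more strongly without it. No measurement among those given explains this gain, so the step records what happens, not why it happens.

The compounds shown leave open whether a small group other than hydrogen at this place, such as fluorine, hydroxyl or ethoxy, would lower the number further or raise it again. They also leave open what happens when the remaining methoxy on this ring is removed or replaced, since compound 3 still carries it.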